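The source may report more compounds than this note shows. Statements on the series, on what has been measured and on what is new or still open speak of the compounds shown alone.

Compound 1 `O=S(=O)(/C=C/c1ccc(F)cc1F)Cc1ccc(Nc2ncnc3ccccc23)cc1` and compound 2 `O=S(=O)(/C=C/c1ccc(C(F)(F)F)cc1F)Cc1ccc(Nc2ncnc3ccccc23)cc1` share one core and differ only in a single group on the outer aromatic ring, a change in which (fluoro in place of trifluoromethyl on an aromatic carbon). In a functional assay on OVCAR-8 cells (Homo sapiens) (on this read-out higher numbers stand for weaker inhibition of growth and lower numbers for stronger inhibition of growth), compound 2 gives 100000 nM. Compound 1 does not give a number in this assay; its reading of > 100000 nM is a limit, and nothing more can be said of it. Hence the step of a number no lower from compound 2 to compound 1 (the limit leaves the size open); the limit of > 100000 nM in this assay, at which 1 of the 3 values shown sits, is where the read-out stops, so the true size of the step is open.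

Compound 3 `O=S(=O)(/C=C/c1ccc(C(F)(F)F)cc1F)Cc1ccc(Nc2ncnc3ccc(Br)cc23)cc1` carries the same outer ring as compound 2, but its core differs by bromo in place of hydrogen on an aromatic carbon. In this assay compound 3 gives 15000 nM, which is the step of a 6.7-fold lower number from compound 2 to compound 3 (0.82 log units; beyond the scatter), and this is the lowest number among the measured compounds.

Compound 4 `O=S(=O)(/C=C/c1ccc(F)cc1F)Cc1ccc(Nc2ncnc3ccc(Br)cc23)cc1` has not yet been measured. It stands to compound 3 as compound 1 stands to compound 2: fluoro in place of trifluoromethyl on an aromatic carbon, with the same surroundings at the site of change, so it is the same change. Compound 4 is therefore expected to give a higher number than compound 3, a step estimated as a 3.3-fold higher number from compound 3 to compound 4 (0.52 log units; beyond the scatter), because the same change gave a number no lower from compound 2 to compound 1 (the limit leaves the size open). My estimate for compound 4 in this assay is 50000 nM. This expected value for compound 4 is likely to fall between 15000 nM and 200000 nM.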

Compound 4, concentration for 50% growth inhibition: 100000 nM
Estimate against measurement, compound 4: 2.0-fold (0.30 log units) below; the measured number falls inside the stated range.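

With the bromo group on the core, replacing trifluoromethyl with fluoro can be read in this assay as a 6.7-fold higher number from compound 3 to compound 4 (0.82 log units; beyond the scatter), so on this core the change goes with weaker inhibition of growth. Compound 1 reads > 100000 nM, which is a limit and not a number. Placing bromo on the core of compound 1 reads as a number no higher from compound 1 to compound 4 (the limit leaves the size open), so the size of this step cannot be read. With the same change reading as a number no lower from compound 2 to compound 1 (the limit leaves the size open) on the core without bromo, the two cores therefore show no reversal in the direction of the change, but they do not show that its size carries over from one core to the other, and a single readable step cannot establish a rule for the series: the same change on two cores in this assay, a number no lower (the limit leaves the size open) from compound 2 to compound 1 and a 6.7-fold higher number (0.82 log units; beyond the scatter) from compound 3 to compound 4; the limit leaves it open whether they differ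

The compounds shown leave open how other groups would read in this assay at the same place on the outer ring, para to the large group, such as a chloro group, a methoxy group or an amine. They also leave open whether the gain seen with bromo on the core in the trifluoromethyl pair would extend to another atom or group there, such as chloro, a nitrile or a carboxylic acid.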